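The compounds below may be only part of what the source reports. "The series", "measured", "known", "first", "only" and "open" are said of these compounds alone.

Measured so far in a functional assay on CHO-K1 cells for antagonist activity at transient receptor potential cation channel subfamily V member 1 (Homo sapiens), read by FLIPR; a higher number here means a weaker inhibitor, a lower number a stronger inhibitor:
Compound 1 `CC1CCC(Nc2nc(C(F)(F)F)ccc2CNC(=O)C(C)c2ccc(NS(C)(=O)=O)c(F)c2)CC1`: 27.2 nM
Compound 2 `CC(C(=O)NCc1ccc(C(F)(F)F)nc1NCc1ccc(Cl)cc1)c1ccc(NS(C)(=O)=O)c(F)c1`: 65.7 nM

Among the compounds with values here, compound 2 holds the higher of the two numbers; compound 1 sits lower by a 2.4-fold higher number from compound 1 to compound 2 (0.38 log units; beyond the scatter), the only measured step in the set.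

Compound 3 `CC(C(=O)NCc1ccc(C(F)(F)F)nc1N1CCCC1)c1ccc(NS(C)(=O)=O)c(F)c1` differs from compound 2 by pyrrolidin-1-yl in place of (4-chlorobenzyl)amino on an aromatic carbon. Within the data shown here, no measured step changes this position in a comparable way; the step from compound 1 to compound 2 exchanged substituents on the nitrogen but kept that nitrogen's hydrogen, which compound 3 gives up. The expectation is therefore loosely held: a modest weakening, estimated as a 2.7-fold higher number from compound 2 to compound 3 (0.44 log units; beyond the scatter), is expected for compound 3, with an estimated value of 180 nM and a range of 50 nM to 700 nM.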

Compound 3, inhibition constant: 0.6 nM
Estimate against measurement, compound 3: 300-fold (2.48 log units) above, outside the stated range (below it).
By their numbers in this assay, from the lowest: compound 3; then compound 1; then compound 2.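

In this assay, pyrrolidin-1-yl at this position gives a far lower number than either amino substituent (a 110-fold lower number from compound 2 to compound 3 (2.04 log units; beyond the scatter); a 45-fold lower number from compound 1 to compound 3 (1.66 log units; beyond the scatter)). Both steps far exceed the exchange of substituents on the retained amino nitrogen (a 2.4-fold higher number from compound 1 to compound 2 (0.38 log units; beyond the scatter)), so a smaller ring group carrying no hydrogen-bond donor is well accepted here. Nothing available explains the gain.

These compounds do not separate loss of the nitrogen's hydrogen from the change in group size. Dimethylamino, piperidin-1-yl or morpholin-4-yl at this position would help to separate them.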